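Changing the Nitrogen Side Chain on a Shared Core

The source may hold more compounds than are shown below. What is called first, only, known or untested is meant among the compounds shown, and "the series" means these compounds.

Results in a functional assay on HCT-116 cells (Homo sapiens) for antiproliferative activity, read by sulforhodamine B assay, with a stated time of 72 h; a higher number here means a weaker inhibitor, a lower number a stronger inhibitor:
- Compound 1 (`COc1ncc(-c2ccc3ncc(NCC4CCCCC4)c(OC)c3c2)cc1NS(=O)(=O)c1ccc(F)cc1F`) gives 13600 nM
- Compound 2 (`COc1ncc(-c2ccc3ncc(NCC4CCN(S(C)(=O)=O)CC4)c(OC)c3c2)cc1NS(=O)(=O)c1ccc(F)cc1F`) gives 1360 nM
- Compound 3 (`COc1ncc(-c2ccc3ncc(NC(=O)CN4CCCC(O)C4)c(OC)c3c2)cc1NS(=O)(=O)c1ccc(F)cc1F`) is not yet measured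

Of the two measured compounds, compound 2 has the lower number and is the stronger inhibitor. Compound 3 alters the group on a nitrogen on an aromatic ring, placing a carbonyl directly on that nitrogen: ((3-hydroxypiperidin-1-yl)methyl)carbonyl in place of (1-(methylsulfonyl)piperidin-4-yl)methyl on a nitrogen on an aromatic ring. Among the compounds with values here, the only measured step, a 10-fold lower number from compound 1 to compound 2 (1.00 log units; beyond the scatter), changed a ring on this side chain and shows that the chain can shift the number substantially. Within the data shown here, no measured compound carries that carbonyl, so no direction can be predicted, and the expected change is a 1.1-fold lower number from compound 2 to compound 3 (0.05 log units; within the scatter). For compound 3 the estimated value in this assay is 1200 nM, with an expected range of 250 nM to 6000 nM.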

Compound 3, half-maximal inhibitory concentration: 1770 nM
Compound 3: the middle estimate sits 1.5-fold (0.17 log units) below what was measured; the measured number falls inside the stated range.
By their numbers in this assay, from the lowest: compounds 2 and 3 (each within the scatter of the next); then compound 1.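

In this assay, placing a carbonyl directly on the nitrogen on an aromatic ring leaves the number level with the (1-(methylsulfonyl)piperidin-4-yl)methyl chain (a 1.3-fold higher number from compound 2 to compound 3 (0.11 log units; within the scatter)), so this position accepts quite different side chains. Measured against cyclohexylmethyl, the same group gives a 7.7-fold lower number from compound 1 to compound 3 (0.89 log units; beyond the scatter), so two unlike chains now both improve on that one. No evidence is available to explain either step.

Whether the hydroxyl on the piperidine matters stays open, since the compounds shown do not separate it from the carbonyl. A carboxylic acid in its place or a longer chain could read differently.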